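The source may report more compounds than this note shows. Statements on the series, on what has been measured and on what is new or still open speak of the compounds shown alone.

Measured in a physicochemical assay for solubility; a higher number here means a more soluble compound, a lower number a less soluble compound:
Compound 1 `CNC(=O)c1cc(C(=O)NCCO)n([C@@H](C)c2ccccc2)n1`: >= 139 ug/mL (a limit)
Compound 2 `CNC(=O)c1cc(C(=O)N[C@H]2[C@@H]3COC[C@@H]32)c([C@@H](C)c2ccccc2)o1`: >= 131 ug/mL (a limit)

In this assay, compound 1 stands only at a limit, >= 139 ug/mL, and not at a number. Compound 3 `CNC(=O)c1cc(C(=O)NC)n([C@@H](C)c2ccccc2)n1`, not yet measured, differs from compound 1 in one place: hydrogen in place of hydroxymethyl on a saturated chain carbon bound to an amide-type nitrogen, so that 2-hydroxyethyl becomes methyl (hydrogen in place of hydroxymethyl on a saturated chain carbon bound to an amide-type nitrogen). Within the data shown here, no measured pair shows this change, so the expectation is a loose one. The expected step, an at least 1.1-fold lower number from compound 1 to compound 3 (0.04 log units; that floor lies within the scatter), is none beyond the usual scatter. For compound 3 the estimated value is 125 ug/mL, with an expected range of 60 ug/mL to 190 ug/mL.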

Compound 3, solubility: >= 88 ug/mL
Compound 3 gave a limit, no number (the forecaster's own chance of this, stated with the estimate: 55%); the middle value lies beyond the limit too.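

Among these compounds, compound 1 and compound 3 both stand only at limits in this assay, so no step between them can be read. The compounds shown leave open whether 2-hydroxyethyl to methyl changes the result in this assay at all.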